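The source may report more compounds than this note shows. Statements on the series, on what has been measured and on what is new or still open speak of the compounds shown alone.

Compound 1 `COC(=O)c1ccc(C2SCC(=O)N2c2ccc(N3CCN(Cc4cc(OC)c(OC)c(OC)c4)CC3)cn2)c(OC)c1` and compound 2 `COC(=O)c1ccc(C2SCC(=O)N2c2ccc(N3CCN(S(=O)(=O)c4ccccc4)CC3)cn2)c(OC)c1` share one core and differ only in the group on the outer piperazine nitrogen. In a functional assay on K562 cells (Homo sapiens) for antiproliferative activity, read by MTT assay and trypan blue exclusion, with a stated time of 72 h (on this read-out lower numbers stand for stronger inhibition and higher numbers for weaker inhibition), compound 1 gives only a limit, > 100000 nM. In this assay, among the measured compounds shown here, compound 2 gives 65600 nM, the sole number so far, because of the limit of > 100000 nM in this assay, at which 1 of the 2 values shown sits. Compound 3 `COC(=O)c1ccc(C2SCC(=O)N2c2ccc(N3CCN(S(=O)(=O)c4ccc([N+](=O)[O-])cc4)CC3)cn2)c(OC)c1` is the next candidate and carries nitro in place of hydrogen on an aromatic carbon, nitro in place of hydrogen on an aromatic carbon. For the measured compounds named here, no measured step between related pairs exists here, so the expected step of a 1.2-fold lower number from compound 2 to compound 3 (0.08 log units; within the scatter) is set within the scatter, in no particular direction. Compound 3 is therefore estimated at 55000 nM, with a range from 20000 nM to 150000 nM.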

Compound 3, half-maximal inhibitory concentration: 65200 nM
Compound 3: middle estimate off by 1.2-fold (0.07 log units), on the low side; measured number inside the range.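

Among the compounds shown here, the change from phenylsulfonyl to (4-nitrophenyl)sulfonyl gives the first readable step, a 1.0-fold lower number from compound 2 to compound 3 (0.00 log units; within the scatter), so this change leaves the number in this assay where it stood. This position therefore shows no response to nitro, but the reading is a narrow one, because the values lie close to a limit of the read-out: the limit of > 100000 nM in this assay, at which 1 of the 3 values shown sits.

On these data alone, what an amine or a carboxylic acid in place of the nitro would give stays open. So does an acetyl group in place of the sulfonyl group on the outer piperazine nitrogen.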